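Swapping fluoro for methoxy on the hydroxyphenyl ring

The source may hold more compounds than are shown below. What is called first, only, known or untested is meant among the compounds shown, and "the series" means these compounds.

Measured compounds:
compound 1, `Nc1ccc(C(=O)/C=C/c2ccc(O)c(F)c2)cc1-c1ccc(F)cc1`, 11700 nM
compound 2, `O=C(/C=C/c1cccc(-c2ccc(F)cc2)c1)c1ccc(O)cc1`, 5120 nM
compound 3, `COc1cc(/C=C/C(=O)c2cccc(-c3cccc(F)c3)c2)ccc1O`, 6830 nM

In a functional assay on HepG2 cells (Homo sapiens) for cytotoxicity, read by sulforhodamine B assay, with a stated time of 48 h (a lower number here means a stronger inhibitor, a higher number a weaker inhibitor), compound 1 gives the highest of the three numbers. Compound 3 lies closest, within the scatter of compound 1, while compound 2 sits beyond the scatter with a lower number. Compound 4, `COc1cc(/C=C/C(=O)c2ccc(N)c(-c3ccc(F)cc3)c2)ccc1O`, is not yet measured. It differs from compound 1 in one place: methoxy in place of fluoro on an aromatic carbon, the methoxy entering on an aromatic carbon ortho to a hydroxy group. Within the data shown here, no step between measured compounds isolates this change, so the step of a 1.3-fold lower number from compound 1 to compound 4 (0.11 log units; within the scatter) is expected to be small, with the number for compound 4 at most modestly lower than that of compound 1. Compound 4 is therefore expected at 9000 nM, within a range from 4000 nM to 20000 nM.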

Compound 4, half-maximal inhibitory concentration: 4300 nM
For compound 4 the middle estimate is 2.1-fold (0.32 log units) above the measured one; low and high end bracket the measured number.
By their numbers in this assay, from the lowest: compounds 4, 2, 3 and 1 (each within the scatter of the next, the first and the last beyond it).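

In this assay the change from 3-fluoro-4-hydroxyphenyl to 4-hydroxy-3-methoxyphenyl gives a 2.7-fold lower number from compound 1 to compound 4 (0.43 log units; beyond the scatter) and so lies beyond the scatter. Among these compounds, this is the first reading of this position with the rest of the core of compound 1 held fixed, and it shows that methoxy ortho to a hydroxy group gives a modest but real step over fluoro. Nothing measured here bears on the reason for this step. From the compounds shown here alone, whether ethoxy or chloro on this carbon would move the number further stays open. Also open, going by these compounds, is whether methoxy in place of fluoro gives a similar step on a core without the amine of compound 1 and compound 4.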